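The source may hold more compounds than are shown below. What is called first, only, known or untested is meant among the compounds shown, and "the series" means these compounds.

Working notes on the series in a functional assay on A549 cells (Homo sapiens) for inhibition; on this read-out lower numbers stand for stronger inhibition and higher numbers for weaker inhibition. Compound 1 `COc1cc2ccc(CCc3ccc4ccccc4c3)cc2cc1O` gives 3590 nM, and compound 3 `COc1cc(/C=C\c2ccc3ccccc3c2)ccc1F` gives 450 nM. Compound 2 `CC(=O)Oc1ccc(/C=C/c2ccc3ccccc3c2)cc1` reads > 5000 nM, which is a limit of the assay and not a number. Within the data shown here, it is the only compound so far without a number, as the count shows: the limit of > 5000 nM in this assay, at which 1 of the 3 values shown sits.

Compound 4 `FC(F)(F)Oc1ccc(/C=C/c2ccc3ccccc3c2)cc1` carries trifluoromethyl in place of acetyl on an oxygen on an aromatic ring, which reads as acetoxy to trifluoromethoxy: trifluoromethyl in place of acetyl on an oxygen on an aromatic ring. Among the measured compounds shown here, no measured pair tests this exchange, so any expectation in this assay is loose. A modest move towards stronger inhibition is expected, and a result at the limit again would not be surprising. The reference points are compound 1 at 3590 nM and compound 3 at 450 nM, which show that numbers can be obtained in this series. The estimated change is an at least 1.6-fold lower number from compound 2 to compound 4 (0.22 log units; that floor lies within the scatter), in the direction of stronger inhibition. For compound 4 the expected value is 3000 nM, with an estimated range of 900 nM to 9000 nM.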

Compound 4, half-maximal inhibitory concentration: > 5000 nM
Compound 4: no number, only a limit; the forecaster's own chance of this, stated with the estimate: 40%; middle value at least 1.6-fold (0.22 log units) from the limit.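

Compound 4, like compound 2, gives only a limit and not a number, so no step can be read between compound 2 and compound 4: the limit of > 5000 nM in this assay, at which 2 of the 4 values shown sit.

The compounds shown leave open whether trifluoromethoxy and acetoxy differ at all in this assay.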